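This account rests on a few compounds, and the source may have more. Where it says the series, first, only, none or still open, it means among the compounds named here.

Working notes on the series. Of the compounds shown here, three of the shared core have been measured in a functional assay on MDA-MB-231 cells (Homo sapiens) for inhibition, read by MTT assay, with a stated time of 72 h; on this read-out higher numbers stand for weaker inhibition and lower numbers for stronger inhibition: compound 1 `O=C(CSc1nc(Nc2ccccc2)c2ccccc2n1)Nc1ccc([N+](=O)[O-])cc1` gives 16800 nM, compound 2 `O=C(CSc1nc(Nc2ccccc2)c2ccccc2n1)Nc1ccc(Cl)c(Cl)c1` gives 14500 nM, and compound 3 `C=CC(=O)Nc1cccc(NC(=O)CSc2nc(Nc3ccccc3Cl)c3ccccc3n2)c1` gives 12700 nM. Within the data shown here, the only single-point step among them, a 1.2-fold lower number from compound 1 to compound 2 (0.06 log units; within the scatter), exchanges the aryl group on the amide-type nitrogen and moves the number by an amount that does not exceed the scatter. Compound 3 returns the smallest of the three numbers, but its gaps to compound 2 and to compound 1 both lie within the scatter, so nothing separates these three on the read-out.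

Compound 4 `C=CC(=O)Nc1cccc(NC(=O)CSc2nc(Nc3cccc(C)c3)c3ccccc3n2)c1` is the next candidate. Against compound 3 the change is 3-methylphenyl in place of 2-chlorophenyl on a nitrogen on an aromatic ring; the amide side of the molecule is untouched. Among the measured compounds shown here, no measured step touches this nitrogen, so the step from compound 1 to compound 2 informs only in a general way: the one aryl swap seen so far, on the other nitrogen, stayed within the scatter. With nothing pointing in either direction, the step of a 1.0-fold higher number from compound 3 to compound 4 (0.01 log units; within the scatter) is expected to stay within the scatter. Compound 4 is therefore estimated at 13000 nM in this assay, with a range from 5000 nM to 35000 nM.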

Compound 4, half-maximal inhibitory concentration: 16800 nM
Compound 4: the middle estimate sits 1.3-fold (0.11 log units) below what was measured, and the stated range covers the measured number.
By their numbers in this assay, from the lowest: compounds 3, 2, 1 and 4 (each within the scatter of the next).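

In this assay, among these compounds, the step of a 1.3-fold higher number from compound 3 to compound 4 (0.12 log units; within the scatter) gives the first reading at the aryl group on a nitrogen on an aromatic ring, and it lies within the scatter. The earlier step concerned only the aryl group on the amide-type nitrogen, so an aryl exchange has now been read on each of the two nitrogens, and neither moves the number beyond the scatter. This exchange leaves the heavy-atom count, the six-membered aromatic ring and the absence of hydrogen-bond donors and acceptors unchanged, and no measurement is available to account for the size of the step.

The reading covers only 2-chlorophenyl and 3-methylphenyl, two closely matched aryl groups, so it does not show that this position tolerates change in general. Going by these compounds, it remains open whether a phenyl ring carrying a carboxylic acid or a dimethylamino group, or a cyclohexyl ring in place of the aryl group, would shift the number on this nitrogen beyond the scatter.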